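The source may hold more compounds than are shown below. What is called first, only, known or untested is meant among the compounds shown, and "the series" means these compounds.

Working notes on the series. In a functional assay on DU-145 cells (Homo sapiens) for inhibition, read by trypan blue exclusion, with a stated time of 96 h (on this read-out lower numbers stand for stronger inhibition of growth and higher numbers for weaker inhibition of growth), compound 1 (`Cc1ccc(S/C(=C/c2cc(Cl)cc(Cl)c2Cl)C(=O)c2ccc(Cl)cc2)cc1`) gives 50000 nM and compound 2 (`COc1ccccc1/C=C(/Sc1ccc(C)cc1)C(=O)c1ccc(Cl)cc1`) gives 25000 nM. Only these two numbers are available, and they lie within the scatter of each other, so compound 2 cannot be separated from compound 1.

The next structure is compound 3 (`Cc1ccc(S/C(=C/c2ccc(Cl)cc2)C(=O)c2ccc(Cl)cc2)cc1`), which has 4-chlorophenyl in place of 2-methoxyphenyl on a double-bonded chain carbon bound to a double-bonded chain carbon.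

Going by the values given here, one measured step bears on this change, as it alters the same place: a 2.0-fold lower number from compound 1 to compound 2 (0.30 log units; within the scatter), with 2-methoxyphenyl in place of 2,3,5-trichlorophenyl. Among the compounds with values here, no measured compound carries 4-chlorophenyl at this place, so the data give no direction. A step no larger than the scatter is therefore expected in this assay, though one measured step is thin support and the range is kept wide.

The expected move is no change at the digits printed from compound 2 to compound 3 (within the scatter). For compound 3 the estimated value is 25000 nM, with an expected range of 8000 nM to 60000 nM.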

Compound 3, concentration for 50% growth inhibition: 10000 nM
Compound 3: the middle estimate sits 2.5-fold (0.40 log units) above what was measured, within the range that was stated.
By their numbers in this assay, from the lowest: compound 3; then compounds 2 and 1 (each within the scatter of the next).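

In this assay, going by these compounds alone, the place on a double-bonded chain carbon bound to a double-bonded chain carbon now shows a response beyond the scatter, with a 2.5-fold lower number from compound 2 to compound 3 (0.40 log units; beyond the scatter) and a 5.0-fold lower number from compound 1 to compound 3 (0.70 log units; beyond the scatter), whereas the only earlier step at this place stayed within it. Among the three groups seen here, 4-chlorophenyl therefore gives the lowest number, while 2-methoxyphenyl and 2,3,5-trichlorophenyl still cannot be separated from each other, and both new steps are only modest in size. Nothing available gives a reason for these steps.

The compounds shown leave open how this place would read with an unsubstituted phenyl, an aminophenyl or a phenyl carrying a carboxylic acid, and so whether 4-chlorophenyl marks a real preference or only the best of three groups. On these data alone, the rest of the shared core is the same in all three compounds, so it also remains open whether the step to 4-chlorophenyl would hold with a different group elsewhere on that core.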